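From Sulfonamide to Primary Amide on the Phenoxyphenyl Ring

The source may report more compounds than this note shows. Statements on the series, on what has been measured and on what is new or still open speak of the compounds shown alone.

Of the compounds shown here, three have been measured in a functional assay on MX1 cells (Homo sapiens) for antiproliferative activity, with a stated time of 72 h; on this read-out lower numbers stand for an effect already at smaller amounts and higher numbers for an effect only at larger amounts of compound. Compound 1 `Cn1cc(-c2ccccc2Oc2ccccc2)ccc1=O` gives 4800 nM. Compound 2 `Cn1cc(-c2ccccc2Oc2ccccc2)cc(N)c1=O` reaches only the limit of > 5000 nM; this is an assay limit, not a number (the limit of > 5000 nM in this assay, at which 1 of the 3 values shown sits). The change an at least 1.0-fold higher number from compound 1 to compound 2 (0.01 log units; that floor lies within the scatter) therefore cannot be sized. Compound 3 `CCS(=O)(=O)Nc1ccc(Oc2ccccc2)c(-c2cn(C)c(=O)c3[nH]ccc23)c1` gives 14 nM, the lowest of the two numbers, far from compound 1. Compound 4 `Cn1cc(-c2cc(C(N)=O)ccc2Oc2ccccc2)c2cc[nH]c2c1=O` carries carbamoyl in place of (ethylsulfonyl)amino on an aromatic carbon. For the measured compounds named here, no measured step touches this position or these groups, so no measured step bears on it. Keeping the amide hydrogen, the number for compound 4 is expected near 40 nM, between 10 nM and 200 nM, an expected step of a 2.9-fold higher number from compound 3 to compound 4 (0.46 log units; beyond the scatter).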

Compound 4, half-maximal effective concentration: 120 nM
Compound 4: middle estimate off by 3.0-fold (0.48 log units), on the low side, within the range that was stated.
By their numbers in this assay, from the lowest: compound 3; then compound 4; then compound 1. At a limit, above all of these: compound 2.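

For the compounds shown here, compounds 3 and 4 give the first reading at this position, para to a phenoxy group, and the group there clearly counts: an 8.6-fold higher number from compound 3 to compound 4 (0.93 log units; beyond the scatter). Even so, the (ethylsulfonyl)amino group is not needed for a measured effect, since compound 4 with carbamoyl still gives 120 nM. Nothing measured here explains the size of this step.

The compounds shown leave open how a carboxylic acid or an amine on this carbon would compare. They also leave open whether a longer chain on the sulfonyl group would lower or raise the number.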